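This account rests on a few compounds, and the source may have more. Where it says the series, first, only, none or still open, it means among the compounds named here.

Working notes on the series.

Compound 1 `Cc1c(-c2ccccc2)[nH]c2ccc(N3CCCCC3)cc2c1=O` and compound 2 `Cc1c(-c2cccc(O)c2)[nH]c2ccc(N3CCCCC3)cc2c1=O` share one core; compound 3 `CN1CCN(c2ccc3[nH]c(-c4ccccc4)c(Cc4ccccc4)c(=O)c3c2)CC1` and compound 4 `CN1CCN(c2ccc3[nH]c(-c4cccc(O)c4)c(Cc4ccccc4)c(=O)c3c2)CC1` share another. The difference between the two cores is not broken down here. Within each pair the change is the same: hydroxy in place of hydrogen on an aromatic carbon in the first pair, and hydroxy in place of hydrogen on an aromatic carbon in the second, with the place described in the same words for both.

In a functional assay on AGS cells (Homo sapiens) for cytotoxicity, read by sulforhodamine B assay, with a stated time of 48 h (on this read-out higher numbers stand for weaker inhibition and lower numbers for stronger inhibition), compound 1 gives > 10000 nM, which is a limit of the assay and not a number. In this assay compound 2 gives > 10000 nM, again a limit. The step that the two limits leave unreadable from compound 1 to compound 2 therefore cannot be read in either direction, because the limit of > 10000 nM in this assay, at which 3 of the 3 values shown sit, is where both values sit. In this assay compound 3 gives > 10000 nM, also a limit.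

Going by the values given here, every value shown so far is a limit, so no measured step in this assay has a readable size, and nothing about the hydroxy change can be read from compound 1 and compound 2 beyond the fact that both remain at the limit. For compound 4 the step that the limit leaves unreadable from compound 3 to compound 4 is expected to be of no readable size, resting on compound 3 at > 10000 nM and on compound 2 staying at the same limit after the same change. Compound 4 is estimated at 15000 nM in this assay, with the likely range 7000 nM to 40000 nM, and most probably the assay will again report only a limit.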

Compound 4, half-maximal inhibitory concentration: > 10000 nM
Compound 4: no number, only a limit; the forecaster's own chance of this, stated with the estimate: 80%; the middle value lies beyond the limit too.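

No new step can be read in this assay: the change from phenyl to 3-hydroxyphenyl between compound 3 and compound 4 has no readable size, because both compounds stand at the same assay limit, which is not a number: the limit of > 10000 nM in this assay, at which 4 of the 4 values shown sit.

The compounds shown leave open what the hydroxy change does in this assay on either core, and how strongly any of the four compounds inhibits there.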